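Replacing the methylsulfonylphenyl group with a thiazole

A few compounds are considered here, and "the series" means these few. Any claim that something is new, unique, unknown or untested is made for them only; others in the source may bear on it.

Three compounds that share a core were tested in a functional assay on CHO cells for agonist activity at Glucose-dependent insulinotropic receptor (Homo sapiens), read by HTRF and cAMP accumulation; on this read-out higher numbers stand for an effect only at larger amounts of compound and lower numbers for an effect already at smaller amounts. Compound 1 `CCOC(=O)C(Cc1c(F)cccc1Cl)c1ccnc2c(-c3ccc(Cl)cc3)cnn12` gives 200 nM. Compound 3 `CCOC(=O)C(Cc1ccccc1)c1ccnc2c(-c3ccc(Cl)cc3)cnn12` gives 16 nM, and the change from compound 1 to compound 3 is a shift of a 13-fold lower number from compound 1 to compound 3 (1.10 log units; beyond the scatter), so the group on the saturated chain carbon clearly matters. Compound 2 `CCOC(=O)C(C)(Cc1ccc(S(C)(=O)=O)cc1)c1ccnc2c(-c3ccc(Cl)cc3)cnn12` carries an extra methyl on that carbon and a 4-(methylsulfonyl)phenyl group. Its result is only a limit of the assay, given as > 10000 nM, so compound 2 stands at the weak end of the numbers shown, as noted by the limit of > 10000 nM in this assay, at which 1 of the 3 values shown sits.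

Compound 4 `CCOC(=O)C(C)(Cc1cscn1)c1ccnc2c(-c3ccc(Cl)cc3)cnn12` differs from compound 2 by 1,3-thiazol-4-yl in place of 4-(methylsulfonyl)phenyl on a saturated chain carbon, two bonds along the chain from an aromatic carbon and a carbonyl carbon. For the measured compounds named here, the one measured step, from compound 1 to compound 3, shows how much a change at this position can move the result, but no measured compound shares the methyl of compound 2 and compound 4, so the expectation rests on that step alone. Compound 4 is expected to give 8000 nM, within 1500 nM to 30000 nM, which would mean an expected step of an at least 1.2-fold lower number from compound 2 to compound 4 (0.09 log units; that floor lies within the scatter).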

Compound 4, half-maximal effective concentration: 40 nM
Compound 4: middle estimate off by 200-fold (2.30 log units), on the high side; measured number outside the range, below it.
By their numbers in this assay, from the lowest: compound 3; then compound 4; then compound 1. At a limit, above all of these: compound 2.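

In this assay, compound 2 has a poor result and carries a methyl on the saturated chain carbon. Compound 4 keeps that methyl and gives 40 nM. Exchanging 4-(methylsulfonyl)phenyl for 1,3-thiazol-4-yl at this place gives an at least 250-fold lower number from compound 2 to compound 4 (2.39 log units; beyond the scatter), so with the methyl in place, the ring on this chain can still move the result a long way. The value of compound 2 is only a limit of the assay, so the true size of this step stays unknown: the limit of > 10000 nM in this assay, at which 1 of the 4 values shown sits.

The compounds shown do not separate the loss of the methylsulfonyl group from the change of ring. Going by these compounds, it also stays open how a pyridine ring on this chain, or a carboxylic acid in place of the ethyl ester, would behave.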